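A few compounds are considered here, and "the series" means these few. Any claim that something is new, unique, unknown or untested is made for them only; others in the source may bear on it.

Measured compounds in an assay for inhibition of Fatty-acid amide hydrolase 1 (Rattus norvegicus); on this read-out lower numbers stand for stronger inhibition and higher numbers for weaker inhibition:
compound 1 `O=C(CCCCCCc1cccnc1)c1ncc(-c2ccccn2)o1` — 32 nM
compound 2 `O=C(CCCCCCc1ccc(Cl)cc1)c1ncc(-c2ccccn2)o1` — 2.7 nM
compound 3 `CSc1ccc(CCCCCCC(=O)c2ncc(-c3ccccn3)o2)cc1` — 2.5 nM

Compound 3 gives the lowest number of the three in this assay, but its gap to compound 2 is within the scatter, so the two cannot be ordered; only compound 1 stands apart, with a number higher than either.

Compound 4 `O=C(CCCCCC(O)c1ccccc1)c1ncc(-c2ccccn2)o1` differs from compound 3 in one place: hydroxy(phenyl)methyl in place of 4-(methylsulfanyl)benzyl on a saturated chain carbon, five bonds along the chain from a carbonyl carbon. The terminal ring thus loses its methylsulfanyl group, a hydroxy group is added, and the chain to the ring is one carbon shorter.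

For the measured compounds named here, no measured step matches this change. The nearest guidance comes from the terminus: a 12-fold lower number from compound 1 to compound 2 (1.07 log units; beyond the scatter) and a 13-fold lower number from compound 1 to compound 3 (1.11 log units; beyond the scatter), both large, while a 1.1-fold lower number from compound 2 to compound 3 (0.03 log units; within the scatter) shows that methylsulfanyl and chloro give equivalent numbers. Going by the values given here, a terminus carrying a hydrogen-bond donor and no substituent on the ring has no direct precedent; by analogy with compound 1, a higher number than compound 3 is expected.

Compound 4 is estimated at 40 nM (range 8 nM to 200 nM), a step of a 16-fold higher number from compound 3 to compound 4 (1.20 log units; beyond the scatter) expected.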

Compound 4, inhibition constant: 35 nM
The estimate for compound 4 lay 1.1-fold (0.06 log units) above the measured number, within the range that was stated.
By their numbers in this assay, from the lowest: compounds 3 and 2 (each within the scatter of the next); then compounds 1 and 4 (each within the scatter of the next).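

In this assay, the step from the substituted benzyl termini to hydroxy(phenyl)methyl is large: a 14-fold higher number from compound 3 to compound 4 (1.15 log units; beyond the scatter) and a 13-fold higher number from compound 2 to compound 4 (1.11 log units; beyond the scatter) are both beyond the scatter. Against the (pyridin-3-yl)methyl terminus, a 1.1-fold higher number from compound 1 to compound 4 (0.04 log units; within the scatter) lies within the scatter, so a six-membered aromatic ring of carbon only does not by itself give the low numbers of compound 2 and compound 3 at this place on the chain. No available evidence accounts for these steps.

The change to compound 4 alters the ring substituent, the hydroxy group and the chain length together, so their separate contributions remain unresolved. Also open, going by these compounds, is whether an amine in place of the hydroxy, or a carboxylic acid on the phenyl ring, would shift the number of compound 4.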